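The source may report more compounds than this note shows. Statements on the series, on what has been measured and on what is new or still open speak of the compounds shown alone.

Measured compounds:
Compound 1 `COc1ccc(Cl)cc1S(=O)(=O)Nc1cncc(C(N)=O)c1`: in an assay on isolated protein for inhibition of alkaline phosphatase, tissue-nonspecific isozyme (Homo sapiens) (a higher number here means a weaker inhibitor, a lower number a stronger inhibitor), compound 1 gives 105 nM.
Compound 2 `COc1ccc(Cl)cc1S(=O)(=O)Nc1cncc(C(=O)N2CCN(C)CC2)c1`: in this assay compound 2 gives "not determined" (no result reported).

Compound 2 therefore stands nowhere on the numbers at hand; only compound 1, which shares its core, carries a figure. The step from compound 2 to compound 3 `CCNC(=O)c1cncc(NS(=O)(=O)c2cc(Cl)ccc2OC)c1` is a single exchange on the carbonyl carbon: ethylamino in place of 4-methylpiperazin-1-yl on a carbonyl carbon. Going by the values given here, no measured pair bears directly on this exchange, and compound 2 itself offers no value to step from. What can be said rests on compound 1, whose smaller amide on the same core gives 105 nM in this assay. Going to ethylcarbamoyl is a modest extension of that amide, so no shift beyond the usual scatter of this assay is expected in either direction, and compound 3 is expected to land near compound 1. The estimate for compound 3 is 150 nM, with a range from 40 nM to 600 nM.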

Compound 3, half-maximal inhibitory concentration: > 20000 nM
Compound 3: only a limit was reported (the forecaster's own chance of this, stated with the estimate: 5%); middle value at least 130-fold (2.12 log units) from the limit.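

Compound 1 alone had said nothing about how the amide nitrogen responds to substitution. Ethyl in place of hydrogen on that nitrogen now gives an at least 190-fold higher number from compound 1 to compound 3 (2.27 log units; beyond the scatter), so on this shared core a single small group at this place is enough for a large change in this assay. For compound 3 the reading is a limit and not a number: the limit of > 20000 nM in this assay, at which 1 of the 3 values shown sits.

The compounds shown leave open whether a smaller group such as methyl on the amide nitrogen, or a carboxylic acid in place of the amide, would stay close to compound 1. Compound 2 carries no number, so whether the ring-bearing 4-methylpiperazin-1-yl amide behaves like the ethylamino amide cannot be read.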